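A few compounds are considered here, and "the series" means these few. Any claim that something is new, unique, unknown or untested is made for them only; others in the source may bear on it.

Measured in an ADME assay on Vero cells (Chlorocebus sabaeus) for cytotoxicity, with a stated time of 3 days; on this read-out higher numbers stand for lower toxicity in this test and lower numbers for higher toxicity in this test:
Compound 1 `C[C@@]1(O)[C@H](O)[C@@H](CO)O[C@H]1n1cnc2c(N)nc(N=[N+]=[N-])nc21`: > 100000 nM, a limit of the assay rather than a number.
Compound 2 `C[C@@]1(O)[C@H](O)[C@@H](CO)O[C@H]1n1cnc2c(N)nc(F)nc21`: > 100000 nM, likewise a limit of the assay rather than a number.

Among the compounds with values here, compound 2 therefore stands at the top of the measured range, and the only other value shown sits there too: the limit of > 100000 nM in this assay, at which 2 of the 2 values shown sit. No cytotoxicity was resolved for either compound within the range of this assay.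

Compound 3 `CONc1nc(N)c2ncn([C@@H]3O[C@H](CO)[C@@H](O)[C@@]3(C)O)c2n1` differs from compound 2 in one place: methoxyamino in place of fluoro on an aromatic carbon. Within the data shown here, the single measured step, a step that the two limits leave unreadable from compound 1 to compound 2, touches the same aromatic carbon, but its size cannot be read because both ends sit at the limit of > 100000 nM in this assay, at which 2 of the 2 values shown sit. So the data give no step of known size to lean on; they show only that two different groups at this carbon both left the half-maximal cytotoxic concentration beyond the reach of this assay.

On that basis the expected step is a number no higher from compound 2 to compound 3 (the limit leaves the size open), nothing beyond the scatter. Compound 3 is estimated at 100000 nM, with a range from 40000 nM to 300000 nM, most likely again reported as a limit.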

Compound 3, half-maximal cytotoxic concentration: > 100000 nM
Compound 3 was reported as a limit (the forecaster's own chance of this, stated with the estimate: 80%); the middle value sits exactly at the limit.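

No step can be read among compound 1, compound 2 and compound 3, since each result is a limit of the assay rather than a number: the limit of > 100000 nM in this assay, at which 3 of the 3 values shown sit.

The compounds shown leave open at what concentration any of them would become toxic to the cells, and whether azido, fluoro and methoxyamino differ at all in this assay.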